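The compounds below may be only part of what the source reports. "The series", "measured", "known", "first", "only" and "open" are said of these compounds alone.

Measured in a functional assay on SMMC-7721 cells (Homo sapiens) for antiproliferative activity, read by MTT assay, with a stated time of 48 h; on this read-out lower numbers stand for stronger inhibition and higher numbers for weaker inhibition:
- Compound 1 `CC(=O)OC/C1=C/C[C@](C)(CCC=C(C)C)/C=C/[C@@H](OC(=O)C=C(C)C)[C@](C)(O)/C=C/C1=O`: 2950 nM
- Compound 2 `CC(C)=CCC[C@]1(C)/C=C/[C@@H](OC(=O)C=C(C)C)[C@](C)(O)/C=C/C(O)/C(C=O)=C\C1`: 730 nM
- Compound 3 `CC(=O)O[C@@H]1/C=C/[C@@](C)(CCC=C(C)C)C/C=C(/CO)C(=O)/C=C/[C@@]1(C)O`: 9870 nM

Of these three, compound 3 gives the highest number and so the weakest inhibition in this assay. Its gaps to both other compounds lie beyond the scatter, the nearer to compound 1 and the wider to compound 2.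

Compound 4 `COCO[C@@H]1/C=C/[C@@](C)(CCC=C(C)C)C/C=C(/CO)C(=O)/C=C/[C@@]1(C)O` has not yet been measured. It departs from compound 3 in one place, with methoxymethyl in place of acetyl on an oxygen on a saturated carbon. Read one bond further out, this is acetoxy to methoxymethoxy.

Among the measured compounds shown here, no two measured compounds differ in only one place, so the data give no direct measure of what this exchange does. The expectation therefore starts from compound 3 at 9870 nM, with no shift beyond the scatter in this assay and no firm direction. A slight move towards stronger inhibition is allowed for, as the value of compound 3 is the highest so far. The estimated change is a 1.2-fold lower number from compound 3 to compound 4 (0.09 log units; within the scatter), which is expected to stay within the scatter. The range is kept wide, since the measured compounds differ in several places at once and leave this exchange untested. For compound 4 the estimate is 8000 nM, with an expected range of 3000 nM to 22000 nM.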

Compound 4, half-maximal inhibitory concentration: > 40000 nM
Compound 4 ended at the assay's limit; the forecaster's own chance of this, stated with the estimate: 10%; at least 5.0-fold (0.69 log units) between middle value and limit.
By their numbers in this assay, from the lowest: compound 2; then compound 1; then compound 3. At a limit, above all of these: compound 4.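

In this assay, exchanging acetyl for methoxymethyl on the oxygen on a saturated carbon gives an at least 4.0-fold higher number from compound 3 to compound 4 (0.60 log units; beyond the scatter), so this place is not indifferent to the exchange, even though the two groups match in heavy atoms and in hydrogen-bond acceptors and the one counted difference is the double bond that leaves with the acetyl. The reading for compound 4 is a limit of the assay and not a number, so the step gives only a minimum size: the limit of > 40000 nM in this assay, at which 1 of the 4 values shown sits. Compounds 1, 2 and 3 differ from one another in several places, so they could not isolate this oxygen, whereas this pair shows that changing the group there alone is enough to move the read-out beyond the scatter.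

The pair does not settle whether the carbonyl of the acetyl is what matters, and a free hydroxyl, a propanoyl ester or a benzoyl ester on the same oxygen would speak to that. It also leaves open how far above the limit compound 4 really lies, and whether the same exchange would act alike on the core of compound 2.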